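A few compounds are considered here, and "the series" means these few. Any claim that something is new, unique, unknown or untested is made for them only; others in the source may bear on it.

For the measured compounds named here, compound 3 `Oc1ccc(-c2nnc(Nc3csc(-c4ccccc4)c3)s2)cc1` is the only member of this small set with a number to its name. In a functional assay on A549 cells (Homo sapiens) for inhibition, read by colorimetric assay and MTT assay, with a stated time of 72 h (a higher number here means a weaker inhibitor, a lower number a stronger inhibitor), compound 3 gives 15000 nM. Its two companions were not determined in this assay: compound 1 `Cc1ccc(-c2cc(Nc3nnc(-c4ccc(C)cc4)s3)cs2)cc1` is recorded as "not determined" (no result reported), and compound 2 `COc1ccc(-c2nnc(Nc3csc(-c4ccc(C)cc4)c3)s2)cc1` is recorded as "not determined" (no result reported), so no number exists for either of them, and compound 3 therefore stands alone rather than being weak or strong relative to anything else shown. Compound 4 `Cc1ccc(-c2cc(Nc3nnc(-c4ccc(O)cc4)s3)cs2)cc1` has yet to be tested. Compound 4 differs from compound 3 in one place: methyl in place of hydrogen on an aromatic carbon. Going by the values given here, no measured pair here shows what such a change does, so nothing in the data speaks for or against a shift in this assay. The change is small, a single carbon added at the rim of one ring, and the expectation is that the step from compound 3 to compound 4 will be a 1.2-fold lower number from compound 3 to compound 4 (0.06 log units; within the scatter), that is, no clear change beyond the usual scatter. For compound 4 in this assay the estimate is 13000 nM, with a range from 5000 nM to 35000 nM.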

Compound 4, half-maximal inhibitory concentration: 6000 nM
Compound 4: the middle estimate sits 2.2-fold (0.34 log units) above what was measured; the measured number falls inside the stated range.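

For the compounds shown here, the earlier compounds offered no measured pair, so this is the first reading of what a change at this position can do. Turning phenyl into 4-methylphenyl, with the methyl para to a large group, gives a 2.5-fold lower number from compound 3 to compound 4 (0.40 log units; beyond the scatter) in this assay, so this position accepts a small added carbon and the number moves modestly in the favourable direction. Nothing shown explains why the methyl has this effect.

This single pair cannot say whether the gain would grow, hold or reverse with a longer chain such as ethyl, or with a different group such as an amine or a carboxylic acid at the same place. Compound 1 and compound 2 also carry the 4-methylphenyl group, but they have no number, so they cannot show whether the step repeats on other members of the series.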